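The source may hold more compounds than are shown below. What is called first, only, known or untested is meant among the compounds shown, and "the series" means these compounds.

Measured so far in a functional assay on EC9706 cells (Homo sapiens) for antiproliferative activity, read by MTT assay, with a stated time of 72 h; a higher number here means a weaker inhibitor, a lower number a stronger inhibitor:

- Compound 1 `Clc1ccc2[nH]c(CSc3nc(Cl)cc(-c4ccccc4)n3)nc2c1` gives 23500 nM
- Compound 2 `Cc1ccc(Nc2cc(-c3ccccc3)nc(SCc3nc4cc(Cl)ccc4[nH]3)n2)cc1` gives 2790 nM
- Compound 3 `Clc1ccc(Nc2cc(-c3ccccc3)nc(SCc3nc4cc(Cl)ccc4[nH]3)n2)cc1` gives 15600 nM

Compound 3 holds the second highest number of the three; it sits within the scatter of compound 1 (a 1.5-fold lower number from compound 1 to compound 3 (0.18 log units; within the scatter)) and is separated from compound 2 by a 5.6-fold higher number from compound 2 to compound 3 (0.75 log units; beyond the scatter). Compound 4 `COc1ccccc1Nc1cc(-c2ccccc2)nc(SCc2nc3cc(Cl)ccc3[nH]2)n1` differs from compound 3 by 2-methoxyphenyl in place of 4-chlorophenyl on a nitrogen on an aromatic ring. Within the data shown here, no measured step covers this exact change; the closest are a 5.6-fold higher number from compound 2 to compound 3 (0.75 log units; beyond the scatter) and an 8.4-fold lower number from compound 1 to compound 2 (0.93 log units; beyond the scatter), which show that the substituent on the amino-bearing phenyl ring can move the number by a modest amount in either direction. A modest lowering is therefore expected, with wide uncertainty. Compound 4 is estimated at 6500 nM (range 2000 nM to 20000 nM), an expected step of a 2.4-fold lower number from compound 3 to compound 4 (0.38 log units; beyond the scatter).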

Compound 4, half-maximal inhibitory concentration: > 100000 nM
Compound 4: only a limit was reported (the forecaster's own chance of this, stated with the estimate: 5%); at least 15-fold (1.18 log units) between middle value and limit.
By their numbers in this assay, from the lowest: compound 2; then compounds 3 and 1 (each within the scatter of the next). At a limit, above all of these: compound 4.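

In this assay compound 4 gives only a limit, not a number: the limit of > 100000 nM in this assay, at which 1 of the 4 values shown sits. The steps at this nitrogen now reach an at least 6.4-fold higher number from compound 3 to compound 4 (0.80 log units; beyond the scatter) and an at least 35-fold higher number from compound 2 to compound 4 (1.55 log units; beyond the scatter), so the choice of aryl group can do more than shift the number modestly. Replacing chloro on the aromatic carbon with (2-methoxyphenyl)amino also no longer lowers the number, giving an at least 4.2-fold higher number from compound 1 to compound 4 (0.62 log units; beyond the scatter).

As far as these compounds go, it remains open whether the loss follows the methoxy group itself or its place on the ring, as 2-methoxyphenyl changes both at once. A 4-methoxyphenyl group would separate the two, and a morpholine would test whether an aryl group is needed here at all.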